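The source may hold more compounds than are shown below. What is called first, only, known or untested is meant among the compounds shown, and "the series" means these compounds.

Of the compounds shown here, two have so far been measured in an ADME assay on the whole organism (Mus musculus, strain ICR) for pharmacokinetics, read by HPLC, with a stated time of 24 h, at a dose of 50 mg/kg by the oral route; a higher number here means more compound in the circulation at the dose given, a lower number less compound in the circulation. Compound 1, `CCc1nc2ccc(Cl)cn2c1C(=O)NCCOc1ccc(N(C)C)cc1`, reaches 5490 nM. Compound 2, `CCc1nc2ccc(Br)cn2c1C(=O)NCCOc1ccc(N2CCCCC2)cc1`, reaches 2090 nM, the lower of the two numbers, and the gap between compound 2 and compound 1 is beyond the scatter of this kind of measurement. The two compounds differ in more than one place, so the gap cannot be pinned on any single change.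

Compound 3, `CCc1nc2ccc(Br)cn2c1C(=O)NCCOc1ccc(N2CCC(C(F)(F)F)CC2)cc1`, has not yet been measured. It differs from compound 2 in one place: trifluoromethyl in place of hydrogen on a saturated ring carbon. Going by the values given here, no measured pair shows this change, so nothing here tells which way it will move the number. The step from compound 2 to compound 3 is expected to be small, a 1.2-fold lower number from compound 2 to compound 3 (0.06 log units; within the scatter), not clearly beyond the scatter in either direction. Compound 3 is therefore estimated to reach 1800 nM, within a range from 600 nM to 5000 nM.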

Compound 3, maximal plasma concentration: 9420 nM
Compound 3: the middle estimate sits 5.2-fold (0.72 log units) below what was measured; the whole stated range lies below it.
By their numbers in this assay, from the lowest: compound 2; then compounds 1 and 3 (each within the scatter of the next).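

Going by these compounds alone, this is the first pair that differs in one place only, so a single change can be read directly: in this assay, replacing piperidin-1-yl with 4-(trifluoromethyl)piperidin-1-yl gives a 4.5-fold higher number from compound 2 to compound 3 (0.65 log units; beyond the scatter). The saturated ring carbon three ring bonds from the ring nitrogen is therefore a position where a change can shift this number, and here trifluoromethyl goes with more compound in the circulation, not less. No measurement at hand explains the rise, so it stands as an observation without a known cause.

One pair cannot show whether this rise is specific to trifluoromethyl or would also appear with a methyl group, a single fluorine atom or a carboxylic acid on the same carbon. It also leaves open what trifluoromethyl would do on another carbon of the same ring.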